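The source may report more compounds than this note shows. Statements on the series, on what has been measured and on what is new or still open speak of the compounds shown alone.

In a functional assay on KG-1 cells (Homo sapiens) for cytotoxicity, read by luminescence and CellTiter-Glo, with a stated time of 3 days (on this read-out lower numbers stand for stronger inhibition and higher numbers for weaker inhibition), compound 1 `COc1ccc(O)c(C(=O)Nc2ccc(C#N)cc2)c1` returns only a limit of the assay, > 10000 nM. Within the data shown here, compound 2 `N#Cc1ccc(NC(=O)c2cc(F)ccc2O)cc1` gives 2670 nM, the only actual number available so far. Among the measured compounds shown here, the one measured step, an at least 3.7-fold lower number from compound 1 to compound 2 (0.57 log units; beyond the scatter), lies beyond the scatter and starts from the limit of > 10000 nM in this assay, at which 1 of the 2 values shown sits. That step, fluoro in place of methoxy, sits at a different place from the change considered next. Compound 3 `O=C(Nc1ccc(OC(F)(F)F)cc1)c1cc(F)ccc1O` keeps the fluoro of compound 2 and carries trifluoromethoxy in place of cyano on an aromatic carbon. For the measured compounds named here, no measured step touches this place, so the size seen from compound 1 to compound 2 offers only a rough scale, and the direction is a tentative judgement. A modest move towards a lower number is expected in this assay, though a result within the scatter would not surprise. The estimated change is a 2.2-fold lower number from compound 2 to compound 3 (0.35 log units; beyond the scatter). For compound 3 the expected value is 1200 nM, within an estimated range of 300 nM to 5000 nM.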

Compound 3, half-maximal inhibitory concentration: 780 nM
The estimate for compound 3 lay 1.5-fold (0.19 log units) above the measured number, within the range that was stated.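

In this assay, trifluoromethoxy in place of cyano on an aromatic carbon, para to a large group, gives a 3.4-fold lower number from compound 2 to compound 3 (0.53 log units; beyond the scatter), so this place, which the earlier step did not touch, also bears on the number. Cyano is therefore not required for a measurable value here, and a group of 5 heavy atoms in place of one of 2 still gives a lower number. This step runs between two actual numbers, whereas the earlier step starts from a limit: the limit of > 10000 nM in this assay, at which 1 of the 3 values shown sits.

The compounds shown leave open how chloro, methyl or an amine would compare at this place, so nothing can yet be said about which feature of trifluoromethoxy matters. They also leave open how much the hydroxy group on the other ring contributes, for instance against a methoxy group or a plain hydrogen.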